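Trimming isopropyl to ethyl: compound 2 to compound 3

The compounds below may be only part of what the source reports. "The series", "measured", "known", "first", "only" and "open" are said of these compounds alone.

Compound 1 `CC1(C)OB([C@H](CCc2ccccc2)NC(=O)N2C/C(=C\c3ccc(F)cc3)C(=O)/C(=C/c3ccc(F)cc3)C2)OC1(C)C`: 1040 nM
Compound 2 `CC(C)[C@H](NC(=O)N1C/C(=C\c2ccc(F)cc2)C(=O)/C(=C/c2ccc(F)cc2)C1)B1OC(C)(C)C(C)(C)O1`: 908 nM

Both compounds were tested in a functional assay on HCT-116 cells (Homo sapiens) for antiproliferative activity, read by MTT assay, with a stated time of 72 h; on this read-out lower numbers stand for stronger inhibition and higher numbers for weaker inhibition. Among the measured compounds shown here, with only two compounds measured, there is little to place compound 2 against, and its one neighbour is compound 1. The gap between them is a 1.1-fold lower number from compound 1 to compound 2 (0.06 log units; within the scatter), so neither can be called the stronger.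

The next compound is compound 3 `CC[C@H](NC(=O)N1C/C(=C\c2ccc(F)cc2)C(=O)/C(=C/c2ccc(F)cc2)C1)B1OC(C)(C)C(C)(C)O1`. It differs from compound 2 by one small edit: hydrogen in place of methyl on a saturated chain carbon bound to two saturated chain carbons. In words, this is hydrogen in place of methyl on a saturated chain carbon bound to two saturated chain carbons, which turns isopropyl into ethyl.

For the measured compounds named here, only one measured step bears on this edit. Replacing phenethyl with isopropyl, a much larger exchange of groups, gave a 1.1-fold lower number from compound 1 to compound 2 (0.06 log units; within the scatter). One step is thin evidence, but it gives no reason to expect a shift beyond the scatter in this assay from this smaller edit. The expected change is a 1.0-fold higher number from compound 2 to compound 3 (0.02 log units; within the scatter). For compound 3 the estimated value is 950 nM, with an expected range from 450 nM to 2000 nM.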

Compound 3, half-maximal inhibitory concentration: 876 nM
For compound 3 the middle estimate is 1.1-fold (0.04 log units) above the measured one, and the stated range covers the measured number.
By their numbers in this assay, from the lowest: compounds 3, 2 and 1 (each within the scatter of the next).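

Trimming the group further still does not separate the compounds in this assay: turning isopropyl into ethyl gives (a 1.0-fold lower number from compound 2 to compound 3 (0.02 log units; within the scatter)), so compound 2 and compound 3 cannot be told apart. The new compound also allows a second, much larger comparison. Hydrogen in place of phenyl at the far end of the chain gives (a 1.2-fold lower number from compound 1 to compound 3 (0.07 log units; within the scatter)), which again lies within the scatter. On the saturated chain carbon bound to an amide-type nitrogen and a boron atom, phenethyl, isopropyl and ethyl therefore give numbers that cannot be ranked in these three compounds, and nothing given here offers a measured reason for this.

On these data alone, all three compounds carry a plain hydrocarbon group at this position, so it remains open whether an amine, a carboxylic acid or a hydroxyl group on this chain would stay within the scatter too. The compounds shown also share the same core and boron group, which leaves open how much those parts contribute to the numbers in this assay.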